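Ortho substituent series: trifluoromethyl replaced by phenoxy

A few compounds are considered here, and "the series" means these few. Any claim that something is new, unique, unknown or untested is made for them only; others in the source may bear on it.

Values in a functional assay on THP-1 cells (Homo sapiens) for inhibition (a lower number here means a stronger inhibitor, a higher number a weaker inhibitor), for the measured compounds:
compound 1, `C[C@H](NC(=O)C(=O)Nc1ccccc1)C(=O)N[C@@H](CC(=O)O)C(=O)COc1c(F)c(F)cc(F)c1F`, gives 140 nM
compound 2, `C[C@H](NC(=O)C(=O)Nc1ccccc1Cl)C(=O)N[C@@H](CC(=O)O)C(=O)COc1c(F)c(F)cc(F)c1F`, gives 540 nM
compound 3, `C[C@H](NC(=O)C(=O)Nc1ccccc1C(F)(F)F)C(=O)N[C@@H](CC(=O)O)C(=O)COc1c(F)c(F)cc(F)c1F`, gives 190 nM

Compound 3 sits second highest of the three numbers in this assay. Its nearest neighbour is compound 1, a difference within the scatter; the step to compound 2 is beyond the scatter.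

Compound 4, `C[C@H](NC(=O)C(=O)Nc1ccccc1Oc1ccccc1)C(=O)N[C@@H](CC(=O)O)C(=O)COc1c(F)c(F)cc(F)c1F`, differs from compound 3 by phenoxy in place of trifluoromethyl on an aromatic carbon.

The bearing steps all concern substitution at the same aromatic carbon. The step of a 3.9-fold higher number from compound 1 to compound 2 (0.59 log units; beyond the scatter) shows a modest loss on adding chloro; the step of a 1.4-fold higher number from compound 1 to compound 3 (0.13 log units; within the scatter) shows no change beyond the scatter on adding trifluoromethyl; the step of a 2.8-fold lower number from compound 2 to compound 3 (0.45 log units; beyond the scatter) shows a modest recovery. Thus the position tolerates a small substituent, and the direction of the effect depends on which group is present. Phenoxy is larger than either chloro or trifluoromethyl, and no measured compound carries a group of that size at this position, so the direction is uncertain.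

The expected step is a 1.7-fold higher number from compound 3 to compound 4 (0.23 log units; within the scatter), a modest loss, given that compound 2 showed 540 nM when a different group was placed there. Compound 4 is therefore estimated at 320 nM, within 100 nM to 1000 nM.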

Compound 4, half-maximal inhibitory concentration: 800 nM
For compound 4 the middle estimate is 2.5-fold (0.40 log units) below the measured one; the measured number falls inside the stated range.
By their numbers in this assay, from the lowest: compounds 1 and 3 (each within the scatter of the next); then compounds 2 and 4 (each within the scatter of the next).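

Phenoxy marks the first limit on what this aromatic carbon accepts in this assay: the tolerance seen for trifluoromethyl does not carry over, with a 4.2-fold higher number from compound 3 to compound 4 (0.62 log units; beyond the scatter) and, against the unsubstituted compound, a 5.7-fold higher number from compound 1 to compound 4 (0.76 log units; beyond the scatter). The step of a 1.5-fold higher number from compound 2 to compound 4 (0.17 log units; within the scatter) places phenoxy level with chloro, so a group with a ring of its own costs no more here than chloro does, and the loss does not follow the heavy-atom count of the substituent, with compound 3 going against any such trend. Nothing available explains why trifluoromethyl is accepted here while phenoxy and chloro are not.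

On these data alone, whether the higher number goes with the oxygen or with the attached ring stays open; a methoxy group or a directly attached phenyl group on this carbon would separate the two. Also open, as far as these compounds go, is whether an amine or a carboxylic acid on this carbon would read like trifluoromethyl or like chloro and phenoxy.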